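This account rests on a few compounds, and the source may have more. Where it says the series, first, only, none or still open, it means among the compounds named here.

Compound 3 `C[C@H]1CCCN1c1c(C#N)c2c(N)ncnc2n1C` has been measured in an assay on isolated protein for binding affinity to Leucine-rich repeat serine/threonine-protein kinase 2 (Homo sapiens), read by TR-FRET and LanthaScreen, with a stated time of 2 h (a lower number here means a stronger inhibitor, a higher number a weaker inhibitor), where compound 3 gives 136 nM. Among the three compounds measured so far, compound 3 carries the highest number. Its nearest companion is compound 2 `CN(C)c1c(C#N)c2c(N)ncnc2n1C`, which in this assay gives 111 nM, a difference within the scatter; the furthest is compound 1 `C[C@@H]1CCCN1c1c(C#N)c2c(N)nc(Nc3ccn(C)n3)cc2n1C`, which in this assay gives 6 nM, a difference beyond the scatter. Compound 4 `Cn1c(N)c(C#N)c2c(N)ncnc21` has not yet been measured. It differs from compound 3 in one place: amino in place of 2-methylpyrrolidin-1-yl on an aromatic carbon. Among the compounds with values here, only one measured step bears on this change, the one in which dimethylamino was exchanged for 2-methylpyrrolidin-1-yl on the same core: a 1.2-fold higher number from compound 2 to compound 3 (0.09 log units; within the scatter). That step lay within the scatter, so exchanging one amine for another left the number much where it was. Within the data shown here, the present change goes further, since the five-membered non-aromatic ring leaves entirely and a single nitrogen enters, and no measured pair shows such a move. A step toward a higher number in this assay is therefore expected, a 2.2-fold higher number from compound 3 to compound 4 (0.34 log units; beyond the scatter). Compound 4 is expected to give 300 nM in this assay, with a range from 100 nM to 1000 nM.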

Compound 4, inhibition constant: 346 nM
Beside the measured number, compound 4's estimate is 1.2-fold (0.06 log units) below it; the measured number falls inside the stated range.
By their numbers in this assay, from the lowest: compound 1; then compounds 2 and 3 (each within the scatter of the next); then compound 4.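

In this assay, amino at this aromatic carbon stands apart from both earlier groups, with a 2.5-fold higher number from compound 3 to compound 4 (0.41 log units; beyond the scatter) and a 3.1-fold higher number from compound 2 to compound 4 (0.49 log units; beyond the scatter), each modest but beyond the scatter. Within the data shown here, the earlier compounds showed only that dimethylamino and 2-methylpyrrolidin-1-yl lie within the scatter of each other, so this is the first change at this position to move the number beyond it, and the presence of the ring alone does not separate compound 4 from the others. No measurement shown here accounts for this shift.

On these data alone, it remains open where methylamino, which lies between amino and dimethylamino in its substitution, or a cyclic amine such as azetidin-1-yl would fall on this core. As far as these compounds go, it is also open whether amino in place of 2-methylpyrrolidin-1-yl would give a similar step on the core of compound 1.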